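The source may report more compounds than this note shows. Statements on the series, on what has been measured and on what is new or still open speak of the compounds shown alone.

In an assay on Sf9 cells for inhibition of protein deacetylase HDAC6 (Homo sapiens), read by fluorescence, with a stated time of 90 min (on this read-out lower numbers stand for stronger inhibition and higher numbers for weaker inhibition), two compounds have been measured. Compound 1 `O=C(NO)c1ccc(COc2c(-c3ccccc3)c3ccccc3n(Cc3ccccc3)c2=O)cc1` carries a benzyl group on the aromatic nitrogen of the shared core and a phenyl group on the neighbouring ring carbon; in this assay compound 1 gives 176 nM. Compound 2 `Cn1c(=O)c(OCc2ccc(C(=O)NO)cc2)c(-c2cccnc2)c2ccccc21` carries a methyl group on that nitrogen and a pyridin-3-yl group in place of the phenyl; in this assay compound 2 gives 46 nM. Of the two numbers, compound 2 stands at the lower one, and the gap to compound 1 lies beyond the usual scatter; since the two compounds differ in two places, the numbers show only that, not which change carries it.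

Compound 3 `O=C(NO)c1ccc(COc2c(-c3cccnc3)c3ccccc3n(Cc3ccccc3)c2=O)cc1` is compound 2 with one change: phenyl in place of hydrogen on a saturated chain carbon bound to an aromatic nitrogen — that is, methyl to benzyl on the aromatic nitrogen, bringing compound 3 to the benzyl group of compound 1 while keeping the pyridin-3-yl group of compound 2. For the measured compounds named here, no pair of measured compounds differs in this place alone, so the size of this step is not known. Taking compound 1 at 176 nM as the only measured carrier of the benzyl group, the step from compound 2 to compound 3 is expected to be a modest rise, a 2.0-fold higher number from compound 2 to compound 3 (0.29 log units; within the scatter), somewhere between no change beyond the scatter and the gap between the two measured compounds. On that basis compound 3 is estimated at 90 nM, with a range from 35 nM to 230 nM.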

Compound 3, half-maximal inhibitory concentration: 25.6 nM
Estimate against measurement, compound 3: 3.5-fold (0.55 log units) above; measured number outside the range, below it.
By their numbers in this assay, from the lowest: compounds 3 and 2 (each within the scatter of the next); then compound 1.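

In this assay, the change from methyl to benzyl on the aromatic nitrogen gives a 1.8-fold lower number from compound 2 to compound 3 (0.25 log units; within the scatter), so with the pyridin-3-yl group in place, compound 2 and compound 3 cannot be told apart and this position accepts the added phenyl ring without a step beyond the scatter. The other change, pyridin-3-yl in place of phenyl on an aromatic carbon, gives a 6.9-fold lower number from compound 1 to compound 3 (0.84 log units; beyond the scatter), and of the two places in which compound 1 and compound 2 differ, only this one now shows a step beyond the scatter with the benzyl group held constant. Nothing available explains the size of either step.

Only methyl and benzyl are shown on the nitrogen and only phenyl and pyridin-3-yl on the aromatic carbon, so it remains open how a longer chain or a chain ending in an amine on the nitrogen, or a pyridin-4-yl group on the carbon, would read. Going by these compounds, it also remains open whether the step from phenyl to pyridin-3-yl keeps its size when methyl rather than benzyl sits on the nitrogen.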